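From 3-chlorophenyl to 4-chlorophenyl: compound 3 and compound 4

A few compounds are considered here, and "the series" means these few. Any claim that something is new, unique, unknown or untested is made for them only; others in the source may bear on it.

Compound 1 `CC(=O)SCCC(CCCCC(=O)O)SC(C)=O` reads "not active" (no number reported)
Compound 2 `CC(=O)SCCC(CCCCC(=O)Nc1ccccc1)SC(C)=O` reads 10.6%
Compound 3 `CC(=O)SCCC(CCCCC(=O)Nc1cccc(Cl)c1)SC(C)=O` reads "not active" (no number reported)

These three compounds share one core and were tested in a functional assay on HO8910 cells (Homo sapiens) for inhibition, read by MTT assay, with a stated time of 24 h, tested at 1 ug/mL; on this read-out higher numbers stand for more inhibition of growth at the one concentration tested and lower numbers for less inhibition of growth. Compound 2 is the only one of them with a number, at 10.6% in this series. Compound 3 has no single number to stand on. Its entry is "not active" (no number reported) and compound 1 carries the same entry, "not active" (no number reported) in the record.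

The next compound to be measured is compound 4 `CC(=O)SCCC(CCCCC(=O)Nc1ccc(Cl)cc1)SC(C)=O`. It has the same atoms as compound 3, joined differently. The structural change is 4-chlorophenyl in place of 3-chlorophenyl on an amide-type nitrogen.

Among the measured compounds shown here, no measured pair shows what a change of this kind does, so the expectation rests only on the values in hand. With compound 2 at 10.6% and compound 3 at "not active" (no number reported) as the nearest neighbours, no step beyond the usual scatter is expected in this assay, in either direction. A report of no activity without a number would fit this expectation just as well as a low reading.

The estimated value for compound 4 is 8% (0% to 20%).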

Compound 4, percent growth inhibition at one concentration: 0.35%
The estimate for compound 4 lay 7.7 percentage points above the measured number; low and high end bracket the measured number.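

In this assay, the series now holds one readable step on the amide-type nitrogen: chloro in place of hydrogen on an aromatic carbon gives a number 10.3 percentage points lower from compound 2 to compound 4 (beyond the scatter). Compound 3, with the 3-chlorophenyl group, has only the entry "not active" (no number reported), so any step between the two chlorophenyl compounds cannot be read, and neither chlorophenyl compound shows a reading above that of compound 2. The data shown offer no measurement that would account for the lower reading of compound 4.

The compounds shown leave open whether this lower reading belongs to chlorine in particular or would also appear with another group in its place on the phenyl ring, such as fluorine, methyl or methoxy. They also leave open how the shared core would read with a benzyl group in place of the phenyl on the amide-type nitrogen, and whether any of these compounds would separate more clearly at a concentration other than the single one tested.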